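A urea in place of an inactive carbamate

The source may report more compounds than this note shows. Statements on the series, on what has been measured and on what is new or still open speak of the compounds shown alone.

Measured in a functional assay on K562 cells (Homo sapiens) for antiproliferative activity, read by MTT assay; on this read-out higher numbers stand for weaker inhibition and lower numbers for stronger inhibition:
Compound 1 `COC(=O)N1CCCc2cc(S(=O)(=O)N3CC(c4ccccc4)NC3=O)ccc21`: > 20000 nM (a limit)
Compound 2 `CCCOC(=O)N1CCCc2cc(S(=O)(=O)N3CC(c4ccccc4)NC3=O)ccc21`: > 20000 nM (a limit)
Compound 3 `C=CCOC(=O)N1CCCc2cc(S(=O)(=O)N3CC(c4ccccc4)NC3=O)ccc21`: 473 nM

Compound 2 stands at > 20000 nM, which is a limit of the assay and not a number. That value is the limit of > 20000 nM in this assay, at which 2 of the 3 values shown sit.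

Compound 4 `NC(=O)N1CCCc2cc(S(=O)(=O)N3CC(c4ccccc4)NC3=O)ccc21` has not yet been measured in this assay. It carries amino in place of propoxy on a carbonyl carbon, a change from propoxycarbonyl to carbamoyl: amino in place of propoxy on a carbonyl carbon.

Three measured steps change the group on this same carbonyl: a step that the two limits leave unreadable from compound 1 to compound 2, an at least 42-fold lower number from compound 1 to compound 3 (1.62 log units; beyond the scatter) and an at least 42-fold lower number from compound 2 to compound 3 (1.62 log units; beyond the scatter). None of them introduces amino, so they give no direct size for this change. Only compound 3 reaches a number, at 473 nM, so a large gain is possible but is not the expected outcome. A result near the limit is expected, with any shift towards lower numbers likely to be modest.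

The step expected is an at least 1.3-fold lower number from compound 2 to compound 4 (0.12 log units; that floor lies within the scatter).

For compound 4 the estimated value is 15000 nM, with an expected range of 1500 nM to 50000 nM.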

Compound 4, half-maximal inhibitory concentration: 3660 nM
Beside the measured number, compound 4's estimate is 4.1-fold (0.61 log units) above it; the range from low to high includes it.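

In this assay, amino on this carbonyl carbon gives a second readable value, so a measurable effect at this position no longer rests on allyloxy alone: an at least 5.4-fold lower number from compound 2 to compound 4 (0.73 log units; beyond the scatter), and an at least 5.4-fold lower number from compound 1 to compound 4 (0.73 log units; beyond the scatter). These two steps are only floors, as compound 1 and compound 2 each stand at a limit and not a number: the limit of > 20000 nM in this assay, at which 2 of the 4 values shown sit. Amino still falls short of allyloxy, with a 7.7-fold higher number from compound 3 to compound 4 (0.89 log units; beyond the scatter), so the allyloxy carbamate remains ahead of the urea.

The compounds shown leave open whether methylamino or dimethylamino on this carbonyl carbon would keep or lose what amino gives. They also leave open whether propargyloxy would behave like allyloxy or like propoxy, and they do not explain the gap between those last two groups.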